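From Three Measured Compounds to a Fourth

A few compounds are considered here, and "the series" means these few. Any claim that something is new, unique, unknown or untested is made for them only; others in the source may bear on it.

Compound 1 `COc1ccc(F)cc1CNCCCNc1ccnc2cc(C3CCCCC3)ccc12`: 4200 nM
Compound 2 `COc1cccc(Oc2ccc3c(NCCCNCc4cc(F)ccc4OC)ccnc3c2)c1`: 14500 nM
Compound 3 `COc1ccc(F)cc1CNCCCNc1ccnc2cc(Cc3cccc(C(F)(F)F)c3)ccc12`: 4200 nM

In a physicochemical assay for solubility, with a stated time of 18 h, at pH 7.4 (a higher number here means a more soluble compound, a lower number a less soluble compound), compound 3 stands level with compound 1 at the digits shown, the two of them giving the lower pair of numbers, while compound 2 sits apart: a 3.5-fold lower number from compound 2 to compound 3 (0.54 log units; beyond the scatter).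

Compound 4 `COc1ccc(F)cc1CNCCCNc1ccnc2cc(Oc3cccc(N(C)C)c3)ccc12` differs from compound 3 in one place: 3-(dimethylamino)phenoxy in place of 3-(trifluoromethyl)benzyl on an aromatic carbon. Among the measured compounds shown here, the step that bears on this is the one between compound 2 and compound 3, where a phenoxy group gave way to the benzyl group, a 3.5-fold lower number from compound 2 to compound 3 (0.54 log units; beyond the scatter). Compound 4 brings a phenoxy group back, so a step of roughly that size in the opposite direction is expected: a 3.1-fold higher number from compound 3 to compound 4 (0.49 log units; beyond the scatter). For compound 4 the estimate is 13000 nM, within a range from 5000 nM to 35000 nM.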

Compound 4, solubility: 14500 nM
For compound 4 the middle estimate is 1.1-fold (0.05 log units) below the measured one; low and high end bracket the measured number.
By their numbers in this assay, from the lowest: compounds 1 and 3 (each within the scatter of the next); then compounds 2 and 4 (each within the scatter of the next).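

In this assay, a second phenoxy group at this position again gives a higher number than the benzyl group (a 3.5-fold higher number from compound 3 to compound 4 (0.54 log units; beyond the scatter)) and also than cyclohexyl (a 3.5-fold higher number from compound 1 to compound 4 (0.54 log units; beyond the scatter)). Dimethylamino in place of methoxy on the phenoxy group leaves the number unmoved (no change at the digits printed from compound 2 to compound 4 (within the scatter)). The two phenoxy compounds therefore stand together, apart from compound 1 and compound 3. Nothing measured here gives the reason for this. Also open, on these data alone, is whether a benzyl group carrying dimethylamino, or a phenoxy group carrying a carboxylic acid, would join the phenoxy pair or the other two.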